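Dichlorophenyl in place of acetyl on the shared core

The compounds below may be only part of what the source reports. "The series", "measured", "known", "first", "only" and "open" are said of these compounds alone.

Two conjugates have been measured in a functional assay on PC-12 cells (Rattus norvegicus) for cytotoxicity, read by MTT assay, with stated times of 3 h and 2 h, tested at 0.1 uM; on this read-out lower numbers stand for a weaker effect and higher numbers for a stronger effect at the one concentration tested. Compound 1 `O=C(CCCCC1CCSS1)NCc1cn(CCCOc2ccc3cc(-c4ccccc4)c(=O)oc3c2)nn1` gives 33.9% in this assay, and compound 2 `CC(=O)c1cc2ccc(OCCCCCn3cc(CNC(=O)CCCCC4CCSS4)nn3)cc2oc1=O` gives 28.9%. Compound 2 therefore carries the lower of the two numbers, yet its gap to compound 1 falls within the scatter, so the two read-outs cannot be told apart. Compound 3 `O=C(CCCCC1CCSS1)NCc1cn(CCCCCOc2ccc3cc(-c4ccc(Cl)c(Cl)c4)c(=O)oc3c2)nn1` has not yet been measured. It differs from compound 2 in a single place: 3,4-dichlorophenyl in place of acetyl on an aromatic carbon, the 3,4-dichlorophenyl sitting on an aromatic carbon of a six-membered aromatic ring with one oxygen, part of a fused or bridged system of two rings. For the measured compounds named here, no measured pair shows the effect of such a change, so any expectation rests on the two numbers alone. Compound 3 is expected to give 35% in this assay, with a range from 22% to 50%. The expected step of a number 6.1 percentage points higher from compound 2 to compound 3 (within the scatter) is small, if anything upward, and likely no larger than the scatter.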

Compound 3, a percentage reported as activity, at one concentration (the size of the read-out at that concentration, not a potency): 39.7%
Beside the measured number, compound 3's estimate is 4.7 percentage points below it; low and high end bracket the measured number.
By their numbers in this assay, from the lowest: compounds 2, 1 and 3 (each within the scatter of the next, the first and the last beyond it).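

In this assay, for the compounds shown here, the replacement of acetyl by 3,4-dichlorophenyl gives the first step that can be read at this position, on an aromatic carbon two atoms from the ring oxygen: a number 10.8 percentage points higher from compound 2 to compound 3 (beyond the scatter). The position therefore accepts an aromatic ring of carbon only in place of a small group with no ring, and the read-out rises modestly rather than falls, even though the hydrogen-bond acceptor of the acetyl group is gone. Nothing available explains why the number moves in this direction.

With a single pair, the compounds shown do not separate the contribution of the added ring from that of its two chlorines or of the lost carbonyl. From the compounds shown here alone, how an amine or a carboxylic acid at this position would read also remains open.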